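The source may report more compounds than this note shows. Statements on the series, on what has been measured and on what is new or still open speak of the compounds shown alone.

Of the compounds shown here, two built on a shared core have been tested in a functional assay on MDA-MB-231 cells (Homo sapiens) for antiproliferative activity, read by MTT assay, with a stated time of 24 h; a lower number here means a stronger inhibitor, a higher number a weaker inhibitor. Compound 1 `COc1ccc(-c2cc(C(=O)/C=C/c3ccccc3)nc3cc(-c4ccccc4)nn23)cc1OC` gives 23300 nM in this assay, and compound 2 `COc1cc(-c2cc(C(=O)/C=C/c3ccc(Cl)cc3)nc3cc(-c4ccccc4)nn23)cc(OC)c1OC` gives 21600 nM. Compound 1 stands at the higher of these two numbers, with compound 2 nearest to it, and the gap between them lies within the usual scatter of repeated measurements. Compound 3 `COc1ccc(-c2cc(/C=C/C(=O)c3ccc(C)cc3)nc3cc(-c4ccccc4)nn23)cc1OC` has not yet been measured. It differs from compound 1 in one place: 2-((4-methylphenyl)carbonyl)ethenyl in place of (2-phenylethenyl)carbonyl on an aromatic carbon. Among the compounds with values here, no measured pair here shows what such a change does, so there is no ground for expecting a step beyond the scatter in either direction. Compound 3 is therefore estimated at 20000 nM in this assay, with a range from 7000 nM to 55000 nM. That estimate corresponds to an expected step of a 1.2-fold lower number from compound 1 to compound 3 (0.07 log units; within the scatter), which is expected to stay inside the scatter.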

Compound 3, half-maximal inhibitory concentration: 19800 nM
For compound 3 the middle estimate is 1.0-fold (0.00 log units) above the measured one, and the stated range covers the measured number.
By their numbers in this assay, from the lowest: compounds 3, 2 and 1 (each within the scatter of the next).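

On the shared core, 2-((4-methylphenyl)carbonyl)ethenyl in place of (2-phenylethenyl)carbonyl gives a 1.2-fold lower number from compound 1 to compound 3 (0.07 log units; within the scatter) in this assay. This first pair with a single point of difference shows that this position accepts a swap that moves the carbonyl along the chain and adds a methyl group to the phenyl ring, with no step beyond the scatter. Nothing measured alongside these numbers explains why the two groups read alike.

From the compounds shown here alone, both alterations arrive together, so the part played by each alone remains unknown, and a step from one could be hidden by an opposite step from the other. Going by these compounds, it also remains open whether a quite different group at this position, such as an amine or a carboxylic acid, would shift the number beyond the scatter.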